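Cyclopentyl in Place of Oxan-4-yl: What to Expect

The source may hold more compounds than are shown below. What is called first, only, known or untested is meant among the compounds shown, and "the series" means these compounds.

Of the compounds shown here, three built on a shared core have been measured in a functional assay on CHO-K1 cells for antagonist activity at melanin-concentrating hormone receptor 1 (Homo sapiens), read by inositol phosphate accumulation; a lower number here means a stronger inhibitor, a higher number a weaker inhibitor. Compound 1 `CCC1(O)CCN(c2nc(C)c3cc(NC(=O)COc4ccc(OC(F)(F)F)cc4)ccc3n2)CC1` gives 59 nM. Compound 2 `CCC1(O)CCN(c2nc(C)c3cc(NC(=O)COc4ccc(Cl)cc4)ccc3n2)CC1` gives 384 nM. Compound 3 `Cc1nc(N2CCN(C3CCOCC3)CC2)nc2ccc(NC(=O)COc3ccc(Cl)cc3)cc12` gives 115 nM, which places it second highest of the three numbers, with compound 1 nearest and compound 2 furthest away. Going by the values given here, the only single-point step among the measured compounds runs from compound 1 to compound 2: a 6.5-fold higher number from compound 1 to compound 2 (0.81 log units; beyond the scatter). That step concerns the group on the aromatic ring at the far end of the molecule and says nothing about the ring-bound amine nitrogen.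

Compound 4 `Cc1nc(N2CCN(C3CCCC3)CC2)nc2ccc(NC(=O)COc3ccc(Cl)cc3)cc12` differs from compound 3 in exactly one place: cyclopentyl in place of oxan-4-yl on an amine nitrogen in a ring. Among the compounds with values here, no measured pair shows what happens when a group on this amine nitrogen is exchanged, so there is nothing to lean on but the general experience that such swaps usually move the number only modestly. The expected step is therefore a 1.0-fold higher number from compound 3 to compound 4 (0.02 log units; within the scatter), no larger than the usual scatter. Compound 4 is estimated at 120 nM in this assay, with a likely range from 40 nM to 360 nM.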

Compound 4, half-maximal inhibitory concentration: 150 nM
Estimate against measurement, compound 4: 1.3-fold (0.10 log units) below; the range from low to high includes it.
By their numbers in this assay, from the lowest: compounds 1, 3 and 4 (each within the scatter of the next, the first and the last beyond it); then compound 2.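

In this assay, going by these compounds alone, this is the first reading of what a change on the amine nitrogen does: oxan-4-yl gives way to cyclopentyl, which has one heavy atom fewer and no ring oxygen, and the result is a 1.3-fold higher number from compound 3 to compound 4 (0.12 log units; within the scatter), so in this pair the number holds without that oxygen. The comparison with the other amine group is larger: 4-cyclopentylpiperazin-1-yl in place of 4-ethyl-4-hydroxypiperidin-1-yl on an aromatic carbon gives a 2.6-fold lower number from compound 2 to compound 4 (0.41 log units; beyond the scatter), which shows that the choice of the whole group at this place on the shared core can move the number beyond the scatter, even though the swap on its nitrogen did not. No measurement is available that explains either step.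

Within the data shown here, only two groups on this nitrogen can be compared, so it remains open whether a much smaller group such as methyl, or a ring carrying an amine or a carboxylic acid, would leave the number as little changed. Also open, on these data alone, is whether a 6.5-fold higher number from compound 1 to compound 2 (0.81 log units; beyond the scatter) seen with the 4-ethyl-4-hydroxypiperidin-1-yl group would recur if trifluoromethoxy and chloro were exchanged on the cyclopentyl compound.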